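Will compound 3 stay tolerated by cells?

The compounds below may be only part of what the source reports. "The series", "measured", "known", "first", "only" and "open" are said of these compounds alone.

- compound 1 `CC(C)(C)N(Cc1ccc([N+](=O)[O-])cc1)C(=O)COC(=O)c1ccc([N+](=O)[O-])o1` with > 100000 nM as a limit
- compound 2 `COc1ccc(CN(C(=O)COC(=O)c2ccc([N+](=O)[O-])o2)C(C)(C)C)cc1` with > 100000 nM as a limit

Both entries come from an ADME assay on HEK-293T cells (Homo sapiens) for cytotoxicity, read by MTT assay, with a stated time of 3 days (a higher number here means that more compound is tolerated, a lower number that less compound is tolerated), and neither is a true number. Compound 2 therefore stands only at a limit, and the record so far is the limit of > 100000 nM in this assay, at which 2 of the 2 values shown sit, with no exact value.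

Compound 3 `CC(C)(C)N(Cc1ccccc1C(F)(F)F)C(=O)COC(=O)c1ccc([N+](=O)[O-])o1` differs from compound 2 by 2-(trifluoromethyl)phenyl in place of 4-methoxyphenyl on a saturated chain carbon bound to an amide-type nitrogen and carries 2-(trifluoromethyl)phenyl in place of 4-methoxyphenyl on a saturated chain carbon bound to an amide-type nitrogen. Among the compounds with values here, the only measured step is a step that the two limits leave unreadable from compound 1 to compound 2 and it offers no size to carry over. Neither compound left the limit in that swap, so no step beyond the scatter is expected in this assay and no direction can be given. The expected change is a number no higher from compound 2 to compound 3 (the limit leaves the size open) for this swap. Compound 3 is estimated at 100000 nM with an expected range from 50000 nM to 200000 nM and may again read only as a limit.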

Compound 3, half-maximal cytotoxic concentration: 65000 nM
Compound 3: middle estimate off by 1.5-fold (0.19 log units), on the high side, within the range that was stated.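

In this assay, compound 3 is the only compound shown with an exact value rather than a limit, so 2-(trifluoromethyl)phenyl on a saturated chain carbon bound to an amide-type nitrogen gives this position its only readable number. Against the 4-methoxyphenyl group the change gives an at least 1.5-fold lower number from compound 2 to compound 3 (0.18 log units; that floor lies within the scatter), and against the 4-nitrophenyl group it gives an at least 1.5-fold lower number from compound 1 to compound 3 (0.18 log units; that floor lies within the scatter), so neither step is shown to exceed the scatter, although each is only a floor and the true gap could be larger. The step between compound 1 and compound 2 cannot be read, since both sit at the same limit: the limit of > 100000 nM in this assay, at which 2 of the 3 values shown sit.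

From the compounds shown here alone, whether the trifluoromethyl group itself matters here remains open. So does how a plain phenyl, or a phenyl carrying an amine or a carboxylic acid, would read at this same place.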